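The source may report more compounds than this note shows. Statements on the series, on what has been measured and on what is new or still open speak of the compounds shown alone.

a functional assay on HT-29 cells (Homo sapiens) for cytotoxicity, read by MTT assay, with a stated time of 72 h (on this read-out higher numbers stand for lower toxicity in this test and lower numbers for higher toxicity in this test), has been run on three compounds. Compound 1 `CSc1ccc(CNc2nc(SC)nc3ncccc23)cc1` gives 8750 nM in this assay. Compound 2 `CCCCC[Se]c1nc(N)c2ccccc2n1` returns only a limit of this assay, > 100000 nM. Compound 3 `COc1ccc(CNc2nc([SeH])nc3ccccc23)cc1` also returns only a limit, > 100000 nM. Compound 2 therefore stands at the limit of > 100000 nM in this assay, at which 2 of the 3 values shown sit, and where it truly lies is not known. Compound 4 `C[Se]c1nc(N)c2ccccc2n1` is not yet measured in this assay and differs from compound 2 in one place: hydrogen in place of butyl on a saturated chain carbon bound to a selenium atom. Within the data shown here, no step between measured compounds is available to guide this change. The expected step is a step that the limit leaves unreadable from compound 2 to compound 4, none beyond the scatter. Compound 4 is expected to give 120000 nM, in the range 30000 nM to 500000 nM, and may again return only a limit.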

Compound 4, concentration lethal to 50% of the cells: > 100000 nM
Compound 4: only a limit was reported; the forecaster's own chance of this, stated with the estimate: 70%; the middle value is on the limit's open side.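

Compound 2 and compound 4 both return only a limit, so no step between them can be read: the limit of > 100000 nM in this assay, at which 3 of the 4 values shown sit.

The compounds shown leave open where compound 2 and compound 4 truly lie, and whether hydrogen in place of butyl changes the read-out at all.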